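A few compounds are considered here, and "the series" means these few. Any claim that something is new, unique, unknown or untested is made for them only; others in the source may bear on it.

Compound 2 `CCOC(=O)NC(=N)c1ccc2[nH]c(-c3cccc(-c4ccccc4O)c3O)cc2c1` stands at the edge of what can be measured. In a physicochemical assay for solubility, in phosphate buffer, at pH 7.4 (on this read-out higher numbers stand for higher solubility and lower numbers for lower solubility), compound 2 gives only a limit, < 10000 nM. Compound 1 `CC(C)(C)ONC(=N)c1ccc2[nH]c(-c3cccc(-c4ccccc4O)c3O)cc2c1` likewise gives only a limit in this assay, < 10000 nM. The step that the two limits leave unreadable from compound 1 to compound 2 is therefore unreadable, as the evidence the limit of < 10000 nM in this assay, at which 2 of the 2 values shown sit, shows. Compound 3 `CC(C)OC(=O)NC(=N)c1ccc2[nH]c(-c3cccc(-c4ccccc4O)c3O)cc2c1` is the next member, and its change from compound 2 is methyl in place of hydrogen on a saturated chain carbon bound to an oxygen next to a carbonyl group and a saturated chain carbon. Going by the values given here, no measured step shows how such a change moves solubility, so compound 3 is expected to stay close to the same limit. The expected step that the limit leaves unreadable from compound 2 to compound 3 is thus small. Compound 3 is estimated at 5000 nM, with a range from 1500 nM to 10000 nM.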

Compound 3, solubility: < 10000 nM
Compound 3 was reported as a limit; the forecaster's own chance of this, stated with the estimate: 80%; the middle value does not contradict the limit.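

Going by these compounds alone, compound 3 also gives only a limit, so no step among compound 1, compound 2 and compound 3 can be read: the limit of < 10000 nM in this assay, at which 3 of the 3 values shown sit. In this assay the compounds shown leave open how far their true values lie from that limit or from each other.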